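The source may report more compounds than this note shows. Statements on the series, on what has been measured and on what is new or still open speak of the compounds shown alone.

Measured in a physicochemical assay for lipophilicity, read by HPLC; a lower number here means a more polar compound, a higher number a more lipophilic compound:
- compound 1 `Nc1ccccc1NC(=O)c1ccc(CNC2=N[C@@H](c3ccccc3)CN2)cc1`: 1.92
- compound 2 `Nc1ccccc1NC(=O)c1ccc(CSC2=N[C@@H](Cc3ccccc3)CO2)cc1`: 5.41

Compound 2 holds the higher of the two numbers, and its gap to compound 1 lies beyond the scatter. Compound 3 `Nc1ccccc1NC(=O)c1ccc(CSC2=N[C@@H](c3cccnc3)CO2)cc1` comes next, with pyridin-3-yl in place of benzyl on a saturated ring carbon. Among the compounds with values here, no measured pair differs in one place only, and the expectation rests on the structural change alone. The expected step is a number 1.51 log units lower from compound 2 to compound 3 (beyond the scatter), downward in this assay and beyond the scatter. For compound 3 the estimated value is 3.9, with an expected range of 3.2 to 4.6.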

Compound 3, distribution coefficient: 3.19
Compound 3: middle estimate off by 0.71 log units, on the high side; measured number below the stated range.
By their numbers in this assay, from the lowest: compound 1; then compound 3; then compound 2.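

Within the data shown here, the change from benzyl to pyridin-3-yl on a saturated ring carbon gives the first comparison that differs in one place only. In this assay it reads as a number 2.22 log units lower from compound 2 to compound 3 (beyond the scatter), so the group on this carbon, next to the ring nitrogen, can move the number by a large step. No measurement at hand accounts for that step.

As far as these compounds go, how much of the step goes with the ring nitrogen and how much with the shorter attachment stays open; pyridin-3-ylmethyl on this carbon would separate the two. From the compounds shown here alone, how an amine or a carboxylic acid there would read also remains open.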